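Removing One Chlorine: What to Expect for Compound 3

The source may hold more compounds than are shown below. What is called first, only, known or untested is meant among the compounds shown, and "the series" means these compounds.

Measured so far in a functional assay on NCI-H1975 cells (Homo sapiens) for antiproliferative activity, read by MTT assay, with a stated time of 72 h; on this read-out higher numbers stand for weaker inhibition and lower numbers for stronger inhibition:
compound 1 `COc1cc2ncnc(Nc3ccc(Cl)c(C(F)(F)F)c3)c2cc1OCCCCC(=O)Nc1ccc(S(N)(=O)=O)cc1` gives 3220 nM
compound 2 `COc1ccccc1Nc1ncnc2cc(OC)c(OCCCCC(=O)Nc3ccc(S(N)(=O)=O)cc3)cc12` gives 8030 nM

Compound 1 stands as the lower of the two numbers in this assay, so it is the stronger inhibitor of this pair. Going by the values given here, the one measured step, a 2.5-fold higher number from compound 1 to compound 2 (0.40 log units; beyond the scatter), swaps the whole 4-chloro-3-(trifluoromethyl)phenyl for a 2-methoxyphenyl and weakens inhibition modestly.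

Compound 3 `COc1cc2ncnc(Nc3ccc(C(F)(F)F)cc3)c2cc1OCCCCC(=O)Nc1ccc(S(N)(=O)=O)cc1` is not yet measured. Its difference from compound 1 is 4-(trifluoromethyl)phenyl in place of 4-chloro-3-(trifluoromethyl)phenyl on a nitrogen on an aromatic ring. Among the compounds with values here, this is a smaller change than the one from compound 1 to compound 2: the trifluoromethyl stays and only the chlorine is absent. Within the data shown here, no measured step isolates this change, so the step of a 2.5-fold higher number from compound 1 to compound 2 (0.40 log units; beyond the scatter) serves only as a loose reference: a larger swap at the same nitrogen cost a modest amount. Losing the chlorine alone is expected to cost less, possibly nothing beyond the scatter, but the direction is more likely towards a higher number. Compound 3 is therefore expected at 5000 nM, within 2000 nM to 13000 nM, meaning an estimated step of a 1.6-fold higher number from compound 1 to compound 3 (0.19 log units; within the scatter).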

Compound 3, half-maximal inhibitory concentration: 12000 nM
For compound 3 the middle estimate is 2.4-fold (0.38 log units) below the measured one, and the stated range covers the measured number.
By their numbers in this assay, from the lowest: compound 1; then compounds 2 and 3 (each within the scatter of the next).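

In this assay this small change at the nitrogen matters: the step is a 3.7-fold higher number from compound 1 to compound 3 (0.57 log units; beyond the scatter) and it costs about as much as the larger swap to the 2-methoxyphenyl. The names also show that more than a lost chlorine is involved: compound 1 carries a 4-chloro-3-(trifluoromethyl)phenyl, whereas compound 3 carries a 4-(trifluoromethyl)phenyl, so the trifluoromethyl does not keep its numbering and this single step cannot be credited to the chlorine alone. Going by these compounds alone, the other new comparison, a 1.5-fold higher number from compound 2 to compound 3 (0.17 log units; within the scatter) and so within the scatter, gives no separation between the 2-methoxyphenyl and the 4-(trifluoromethyl)phenyl, leaving the 4-chloro-3-(trifluoromethyl)phenyl of compound 1 as the only group here that stands apart from the others.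

The compounds shown leave open how a 4-chlorophenyl or a 3-(trifluoromethyl)phenyl on the same nitrogen would compare, and such groups would help separate what each substituent on compound 1 contributes. Nothing available explains why this change in the ring weakens inhibition.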